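From Propyl to tert-Butyl on a Shared Core

This account rests on a few compounds, and the source may have more. Where it says the series, first, only, none or still open, it means among the compounds named here.

Two compounds with a shared core have been examined in a functional assay on HT-1080 cells (Homo sapiens), read by transwell migration, with a stated time of 24 h, tested at 10 uM; a lower number here means a stronger effect, a higher number a weaker effect of the compound at the concentration tested. Compound 1 `CC(=O)OCc1ccc2oc(=O)c(C(=O)Sc3cccc(Cl)c3)cc2c1` gives 61.9%, while compound 2 `CCCC(=O)OCc1ccc2oc(=O)c(C(=O)Oc3cccc(Br)c3)cc2c1` gives 24.7%, the lower of the two numbers, with compound 1 standing higher by a margin beyond the usual scatter. The two compounds differ in more than one place, so their values are simply set side by side. Compound 3 `CC(C)(C)C(=O)OCc1ccc2oc(=O)c(C(=O)Oc3cccc(Br)c3)cc2c1` has not yet been measured in this assay. It differs from compound 2 by tert-butyl in place of propyl on a carbonyl carbon. For the measured compounds named here, with no single-change step among the measured compounds to guide the size of this change, only a modest shift is expected, and it may not reach beyond the scatter in either direction. Compound 3 is therefore estimated at 30% in this assay, with a range from 15% to 50%. That estimate amounts to an expected step of a number 5.3 percentage points higher from compound 2 to compound 3 (within the scatter).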

Compound 3, a percentage reported as activity, at one concentration (the size of the read-out at that concentration, not a potency): 23.6%
Compound 3: middle estimate off by 6.4 percentage points, on the high side, within the range that was stated.
By their numbers in this assay, from the lowest: compounds 3 and 2 (each within the scatter of the next); then compound 1.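

In this assay, for the compounds shown here, tert-butyl in place of propyl on a carbonyl carbon comes with a number 1.1 percentage points lower from compound 2 to compound 3 (within the scatter), and this is the first single-change step available. Going by these compounds alone, until now, the only comparison was between compounds that differ in more than one place, so nothing could be said about this position alone. The step shows that, with the rest of the structure of compound 2 held fixed, this exchange leaves the reading unchanged within the scatter, and nothing at hand gives a reason for that outcome. The compounds shown leave open whether a longer chain such as octyl, or an amine carried on that carbonyl carbon, would also stay within the scatter of compound 2. Also open, as far as these compounds go, is whether the same exchange would read alike in the setting of compound 1.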